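An Acetamide Head Group in Place of the Ester

The compounds below may be only part of what the source reports. "The series", "measured", "known", "first", "only" and "open" are said of these compounds alone.

Three compounds share a core in which a basic ring carries a propyl chain that ends in an aryl ether, and all were tested in a functional assay (aorta) with Oryctolagus cuniculus as the target; a higher number here means weaker binding, a lower number tighter binding. Compound 1 `COc1cc(C(C)=O)ccc1OCCCN1CCC(C(c2ccccc2)c2ccc(F)cc2)CC1` gives 6.31 nM. Compound 2 `COc1cc(C(C)=O)ccc1OCCCN1CCC(C(c2ccc(F)c(F)c2)c2ccc(F)c(F)c2)CC1` gives 2.51 nM. Compound 3 `COC(=O)c1ccc(OCCCN2CCC(C(c3ccc(F)cc3)c3ccc(F)cc3)CC2)c(OC)c1` gives 1.26 nM, the lowest of the three numbers; compound 2 sits within the usual scatter of it, while compound 1 lies beyond that scatter. No two of these compounds differ in only one place, so no single change can be read off from the measured set.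

Compound 4 `CC(=O)Nc1ccc(OCCCN2CCC(C(c3ccc(F)cc3)c3ccc(F)cc3)CC2)cc1` has not been measured. It differs from compound 3 at the aryl ether end: 4-acetamidophenyl in place of 2-methoxy-4-(methoxycarbonyl)phenyl on an oxygen on a saturated carbon. The change drops the methoxy and methoxycarbonyl groups and brings in an acetamido group carrying one hydrogen-bond donor, a feature none of the three measured compounds has. Since the measured compounds differ in fluorine substitution and head group yet span only a modest range, no large jump is expected. The step of a 2.5-fold higher number from compound 3 to compound 4 (0.40 log units; beyond the scatter) is expected to be a small move toward a higher number, one that may not pass beyond the scatter. Compound 4 is estimated at 3.2 nM, within a range from 1 nM to 12 nM.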

Compound 4, dissociation constant: 12.6 nM
Compound 4: middle estimate off by 3.9-fold (0.60 log units), on the low side, and the stated range ends below it.
By their numbers in this assay, from the lowest: compounds 3 and 2 (each within the scatter of the next); then compounds 1 and 4 (each within the scatter of the next).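

With the rest of the molecule held fixed, placing 4-acetamidophenyl in place of 2-methoxy-4-(methoxycarbonyl)phenyl on an oxygen on a saturated carbon gives, in this assay, a 10-fold higher number from compound 3 to compound 4 (1.00 log units; beyond the scatter). Among the compounds shown here, this is the first direct evidence that the number in this assay responds to the group at the aryl ether end, something compounds 1, 2 and 3 could not show, as each pair among them differs in more than one place. The data offer no measured explanation for the size of this step.

For the compounds shown here, the single step changes several things together, removing the methoxy and methoxycarbonyl groups and bringing in the acetamido group with its amide hydrogen, so the share of each in the step remains unresolved. On these data alone, how an amine or a carboxylic acid would compare with the methoxycarbonyl group at this end of the shared core also remains open, as does whether a methoxy group kept alongside the acetamido group would alter the result.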